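The compounds below may be only part of what the source reports. "The series", "measured", "known", "first", "only" and "open" are said of these compounds alone.

Compound 1, `Cn1cc(-c2nc3ccccc3n2C(=O)c2ccccc2Br)c2ccccc21`, is the starting point of this series. In a functional assay on HepG2 cells (Homo sapiens) for inhibition, read by MTT assay, with a stated time of 24 h (on this read-out lower numbers stand for stronger inhibition of growth and higher numbers for weaker inhibition of growth), compound 1 gives 68200 nM. Compound 2, `COc1ccc2c(c1)c(-c1nc3ccccc3n1C(=O)c1ccccc1Br)cn2C`, carries methoxy in place of hydrogen on an aromatic carbon relative to compound 1, and in this assay compound 2 gives 54200 nM, so that the step of a 1.3-fold lower number from compound 1 to compound 2 (0.10 log units; within the scatter) is small. Compound 3, `Cn1cc(-c2nc3ccccc3n2C(=O)c2ccccc2)c2cc(Br)ccc21`, has the same atoms as compound 1 joined differently; the difference between the two cores is not broken down here. In this assay compound 3 gives 48100 nM, and the values of compound 3 and compound 2 stand within the scatter of one another.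

Compound 4, `COc1ccccc1C(=O)n1c(-c2cn(C)c3ccc(Br)cc23)nc2ccccc21`, has not yet been measured. It differs from compound 3 by methoxy in place of hydrogen on an aromatic carbon. This is the same kind of change as that from compound 1 to compound 2, not the same: there the methoxy sat on a ring that is part of a fused system, meta to a fused ring and para to a fused ring, whereas here it sits on a six-membered ring of carbon only, ortho to a large group. Because the earlier step of a 1.3-fold lower number from compound 1 to compound 2 (0.10 log units; within the scatter) lay within the scatter, compound 4 is expected to show a step of a 1.2-fold lower number from compound 3 to compound 4 (0.08 log units; within the scatter) in this assay. The estimate for compound 4 is 40000 nM, expected to fall between 20000 nM and 80000 nM.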

Compound 4, concentration for 50% growth inhibition: 34600 nM
Compound 4: the middle estimate sits 1.2-fold (0.06 log units) above what was measured; the range from low to high includes it.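

In this assay, methoxy in place of hydrogen gives a 1.4-fold lower number from compound 3 to compound 4 (0.14 log units; within the scatter), so on this core too the change stays within the scatter. Set beside the earlier step, the two agree: the same change on two cores in this assay, a 1.3-fold lower number (0.10 log units; within the scatter) from compound 1 to compound 2 and a 1.4-fold lower number (0.14 log units; within the scatter) from compound 3 to compound 4, 1.1-fold (0.04 log units) apart, within the scatter of two such steps. Going by these compounds alone, this shows only that in these two pairs the change has a small step of similar size on both cores; neither step is beyond the scatter, so it does not show a real gain in growth inhibition that carries from one core to the other, and with the methoxy on a different ring in each pair and just two pairs to compare, it sets no general rule for the series.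

The compounds shown leave open whether a group other than methoxy, such as an amine, a carboxylic acid or a longer chain, placed on the six-membered aromatic ring of carbon only, would give a step beyond the scatter in this assay. As far as these compounds go, whether the methoxy step would stay this small on other cell lines also remains open.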